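From carboxy to 3,4-dichlorophenyl: a step beyond two limits

A few compounds are considered here, and "the series" means these few. Any claim that something is new, unique, unknown or untested is made for them only; others in the source may bear on it.

- Compound 1 `C=C[C@@](C)(/C=C/c1ccc(O)c(CO)c1)CCC=C(C)C`: > 49000 nM, a limit
- Compound 2 `C=C[C@@](C)(/C=C/c1ccc(O)c(/C=C/C(=O)O)c1)CCC=C(C)C`: > 49000 nM, a limit
- Compound 3 `C=C[C@@](C)(/C=C/c1ccc(O)c(/C=C/c2ccc(Cl)c(Cl)c2)c1)CCC=C(C)C`: not yet measured

In a functional assay on Jurkat cells (Homo sapiens) for cytotoxicity, with a stated time of 72 h (on this read-out higher numbers stand for an effect only at larger amounts of compound and lower numbers for an effect already at smaller amounts), compound 2 stands only at a limit, > 49000 nM. Compound 3 carries 3,4-dichlorophenyl in place of carboxy on a double-bonded chain carbon bound to a double-bonded chain carbon. Going by the values given here, the one measured step, a step that the two limits leave unreadable from compound 1 to compound 2, offers no size to carry over, and the data end at the limit of > 49000 nM in this assay, at which 2 of the 2 values shown sit. With so large a change, a step towards smaller amounts is tentatively expected, although compound 3 may also return only a limit. The expected step is an at least 2.2-fold lower number from compound 2 to compound 3 (0.34 log units; beyond the scatter). Compound 3 is estimated at 22000 nM, with an expected range of 6000 nM to 60000 nM.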

Compound 3, half-maximal effective concentration: > 49000 nM
Compound 3 ended at the assay's limit (the forecaster's own chance of this, stated with the estimate: 45%); middle value at least 2.2-fold (0.34 log units) from the limit.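

In this assay, compound 2 and compound 3 both stop at a limit, so no step between them can be read: the limit of > 49000 nM in this assay, at which 3 of the 3 values shown sit.

The compounds shown leave open whether 3,4-dichlorophenyl and carboxy differ at all on this read-out.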